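Iodo-methylphenyl Sulfonamide Expected Close to Bromophenyl Parent

The source may report more compounds than this note shows. Statements on the series, on what has been measured and on what is new or still open speak of the compounds shown alone.

Of the compounds shown here, three have been measured in an assay on HeLa cells for binding affinity to 5-hydroxytryptamine receptor 6 (Homo sapiens); on this read-out lower numbers stand for stronger inhibition and higher numbers for weaker inhibition. Compound 1 `COc1ccc(NS(=O)(=O)c2cccc(C#N)c2)cc1N1CCN(C)CC1` gives 63.1 nM, compound 2 `COc1ccc(NS(=O)(=O)c2ccc3c(Cl)cccc3c2)cc1N1CCN(C)CC1` gives 0.794 nM, and compound 3 `COc1ccc(NS(=O)(=O)c2ccc(Br)cc2)cc1N1CCN(C)CC1` gives 5.01 nM. Compound 3 therefore stands second highest of the three numbers, between compound 2 and compound 1. Among the compounds with values here, the only measured step at the group on the sulfonyl sulfur, a 13-fold lower number from compound 1 to compound 3 (1.10 log units; beyond the scatter), shows that this group can move the number strongly. Compound 4 `COc1ccc(NS(=O)(=O)c2cc(I)ccc2C)cc1N1CCN(C)CC1` carries 5-iodo-2-methylphenyl in place of 4-bromophenyl on a sulfonyl sulfur. The values of compound 2 and compound 3 show that a larger group in this place went with a lower number. A small downward step is therefore expected, a 1.6-fold lower number from compound 3 to compound 4 (0.19 log units; within the scatter). Compound 4 is expected to give 3.2 nM in this assay, within 0.8 nM to 12 nM.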

Compound 4, inhibition constant: 1 nM
The estimate for compound 4 lay 3.2-fold (0.51 log units) above the measured number, and the stated range covers the measured number.
By their numbers in this assay, from the lowest: compounds 2 and 4 (each within the scatter of the next); then compound 3; then compound 1.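

In this assay, the group on the sulfonyl sulfur still has room to lower the number: 5-iodo-2-methylphenyl gives a 5.0-fold lower number from compound 3 to compound 4 (0.70 log units; beyond the scatter) and, against the nitrile-bearing ring, a 63-fold lower number from compound 1 to compound 4 (1.80 log units; beyond the scatter), both beyond the scatter. Within the data shown here, with only one six-membered aromatic ring in this place, compound 4 lies within the scatter of compound 2. Nothing shown here explains these steps.

From the compounds shown here alone, this change swaps bromine for iodine, moves the halogen and adds a methyl together, so the share of each stays open. Going by these compounds, whether an amine or a carboxylic acid on this ring would keep the number low is also open.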